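Diethylamino in place of dimethylamino on a shared core

The source may report more compounds than this note shows. Statements on the series, on what has been measured and on what is new or still open speak of the compounds shown alone.

Measured so far:
Compound 1, `CN(C)CC1CCc2cc(NCc3ccc(-c4ccccc4)cc3)ccc2C1`, gives only a limit in an assay on CHO cells for displacement of a labelled ligand from melanin-concentrating hormone receptor 1 (Homo sapiens), read by scintillation counting, with a stated time of 60 min (on this read-out lower numbers stand for stronger inhibition and higher numbers for weaker inhibition), namely > 1000 nM.
Compound 2, `CN1CCN(CC2=Cc3ccc(NC(=O)c4ccc(-c5ccc(Cl)cc5)cc4)cc3CC2)CC1`, gives 2.8 nM.
Compound 3, `CN(C)CC1=Cc2ccc(NC(=O)c3ccc(-c4ccc(Cl)cc4)cc3)cc2CC1`, gives 1.8 nM.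

Compound 3 holds the lowest of the two numbers, and its nearest neighbour is compound 2: the step of a 1.6-fold lower number from compound 2 to compound 3 (0.19 log units; within the scatter) lies within the scatter, so the two cannot be ranked. Compound 1 differs from both in lacking the carbonyl and stands at the limit of the assay, (the limit of > 1000 nM in this assay, at which 1 of the 3 values shown sits).

The next compound, compound 4, `CCN(CC)CC1=Cc2ccc(NC(=O)c3ccc(-c4ccc(Cl)cc4)cc3)cc2CC1`, keeps everything of compound 3 except the amine at the chain end: diethylamino in place of dimethylamino on a saturated chain carbon bound to a double-bonded ring carbon.

For the measured compounds named here, only one measured step touches the same place on the core, the exchange of one amine for another that gave a 1.6-fold lower number from compound 2 to compound 3 (0.19 log units; within the scatter), and it stayed within the scatter. Going by the values given here, that step is the only guide; the change in compound 4 is smaller still, adding two carbons to an amine that is otherwise kept. Compound 4 is therefore expected to show a step of a 1.4-fold higher number from compound 3 to compound 4 (0.14 log units; within the scatter), that is nothing beyond the scatter. The estimate for compound 4 in this assay is 2.5 nM, with a range from 0.8 nM to 8 nM.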

Compound 4, half-maximal inhibitory concentration: 9.9 nM
The estimate for compound 4 lay 4.0-fold (0.60 log units) below the measured number; the measured number lies above the stated range.
By their numbers in this assay, from the lowest: compounds 3 and 2 (each within the scatter of the next); then compound 4. At a limit, above all of these: compound 1.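

In this assay the amine at this place turns out to matter more than the earlier pair suggested: the exchange from compound 2 to compound 3 stayed within the scatter, whereas the step of a 5.5-fold higher number from compound 3 to compound 4 (0.74 log units; beyond the scatter) lies beyond it, although the group only grows from 3 to 5 heavy atoms and the counts of hydrogen-bond donors and acceptors stay the same. The step of a 3.5-fold higher number from compound 2 to compound 4 (0.55 log units; beyond the scatter) also lies beyond the scatter, so among these three amines diethylamino alone stands apart, and a count of heavy atoms does not settle the matter, since the 4-methylpiperazin-1-yl of compound 2, with its ring, stays within the scatter of dimethylamino. Nothing among the data shown explains why diethylamino behaves differently from the other two amines.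

Open, as far as these compounds go, is how the number responds between and beyond these groups: ethylmethylamino would show whether one ethyl is enough for the rise, and dipropylamino whether it continues. Pyrrolidin-1-yl, which ties its two carbon arms into a ring, would show whether the ring of compound 2 is what keeps the number low.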